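This account rests on a few compounds, and the source may have more. Where it says the series, first, only, none or still open, it means among the compounds named here.

Compound 1 `CN(Cc1cccc(F)c1)[C@H]1C2C3CC4C2C(=O)C2C4C3C21` gives 303 nM in an assay on brain for displacement of a labelled ligand from Sigma non-opioid intracellular receptor 1 (Rattus norvegicus); a lower number here means a stronger inhibitor, a higher number a weaker inhibitor.
Compound 2 `CN(Cc1cccnc1)[C@H]1C2C3CC4C2C(=O)C2C4C3C21` gives 734 nM in this assay.
Compound 3 `CN(Cc1ccccc1)[C@H]1C2C3CC4C5C3CC2C5C41` gives 770 nM in this assay.

Compound 3 has the highest of the three numbers in this assay; its value sits within the scatter of compound 2 and lies beyond the scatter from compound 1. Compound 4 `CN(CC1CCCCC1)[C@H]1C2C3CC4C5C3CC2C5C41` differs from compound 3 by cyclohexyl in place of phenyl on a saturated chain carbon bound to an amine nitrogen. Within the data shown here, no measured step swaps an aromatic ring for a saturated one; the only measured step, a 2.4-fold higher number from compound 1 to compound 2 (0.38 log units; beyond the scatter), changes one aromatic ring for another on the same chain carbon and was modest. With nothing bearing directly on this change, compound 4 is expected to show no step beyond the scatter in this assay, with a 1.3-fold lower number from compound 3 to compound 4 (0.11 log units; within the scatter). Compound 4 is therefore estimated at 600 nM, between 200 nM and 1800 nM.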

Compound 4, inhibition constant: 15 nM
Estimate against measurement, compound 4: 40-fold (1.60 log units) above; measured number below the stated range.
By their numbers in this assay, from the lowest: compound 4; then compound 1; then compounds 2 and 3 (each within the scatter of the next).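

In this assay, the ring on a saturated chain carbon bound to an amine nitrogen proves far more decisive than the earlier aromatic exchange on another core suggested: cyclohexyl in place of phenyl gives a 51-fold lower number from compound 3 to compound 4 (1.71 log units; beyond the scatter). Both groups are six-carbon rings without hydrogen-bond donors or acceptors, and the computed difference is that one ring is aromatic and the other is not. No available evidence accounts for the size of this step. As far as these compounds go, it remains open whether cyclohexyl has the same effect on the core of compound 1, and whether cyclopentyl, an open hexyl chain or piperidine would match it.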